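The source may hold more compounds than are shown below. What is called first, only, known or untested is meant among the compounds shown, and "the series" means these compounds.

Measured so far in an ADME assay on PC-3 cells (Homo sapiens) for cytotoxicity, read by WST assay, tested at 100 uM; on this read-out lower numbers stand for less inhibition and higher numbers for more inhibition at the one concentration tested (going by the name of the read-out):
compound 1 `O=C(Nc1cccc([N+](=O)[O-])c1)C1CCCN(C(=O)c2cc(C(F)(F)F)cc(C(F)(F)F)c2)C1` gives 9%
compound 2 `O=C(Nc1ccc(Cl)cc1)C1CCCN(C(=O)c2cccc([N+](=O)[O-])c2)C1` gives 0%
compound 3 `O=C(Nc1ccc(Cl)cc1)C1CCCN(C(=O)c2cccc(-c3cccs3)c2)C1` gives 4%

Compound 1 has the highest of the three numbers, but its gaps to compound 3 and to compound 2 are both within the scatter, so no order among them can be claimed. Within the data shown here, the only step between measured compounds, a number 4 percentage points higher from compound 2 to compound 3 (within the scatter), is also within the scatter. Compound 4 `O=C(Nc1cccc(Cc2ccccc2)c1)C1CCCN(C(=O)c2cc(C(F)(F)F)cc(C(F)(F)F)c2)C1` differs from compound 1 by benzyl in place of nitro on an aromatic carbon. Among the measured compounds shown here, no measured step exchanges a nitro for a benzyl, so the expectation rests on the flat picture across all three compounds and on the small size of a number 4 percentage points higher from compound 2 to compound 3 (within the scatter). Compound 4 is therefore expected to show no step beyond the scatter, a number 1 percentage points lower from compound 1 to compound 4 (within the scatter), with an estimate of 8% in the range 0% to 20%.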

Compound 4, a percentage reported as inhibition, at one concentration (the size of the read-out at that concentration, not a potency): 0%
Beside the measured number, compound 4's estimate is 8 percentage points above it; the measured number falls inside the stated range.
By their numbers in this assay, from the lowest: compounds 2, 4, 3 and 1 (each within the scatter of the next).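

In this assay, among these compounds, the exchange of nitro for benzyl gives a number 9 percentage points lower from compound 1 to compound 4 (within the scatter), the first measured step at this place on the ring. A larger group with a six-membered aromatic ring of carbon only therefore produces no step beyond the scatter here, and the picture stays flat. No available evidence bears on this result.

From the compounds shown here alone, whether an amine or a carboxylic acid in place of the nitro would give a step beyond the scatter stays open. So does whether a longer chain joining the added phenyl ring would do so.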